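This account rests on a few compounds, and the source may have more. Where it says the series, first, only, none or still open, it means among the compounds named here.

Measured compounds and their results:
Compound 1, `CC1CC(=O)N(CC(=O)N2CCN(c3cccc(Cl)c3)CC2)C1=O`, gives in a functional assay on the whole organism (strain CD1) with Mus musculus as the target, in the maximal electroshock model, with a stated time of 0.5 h (a lower number here means that less compound is needed, a higher number that more compound is needed for the effect), the value 100 mg/kg.
Compound 2, `CC1CC(=O)N(CC(=O)N2CCN(c3ccccc3)CC2)C1=O`, gives in this assay the value 300 mg/kg.
Compound 3, `CCC1(C)CC(=O)N(CC(=O)N2CCN(c3cccc(C(F)(F)F)c3)CC2)C1=O`, gives in this assay the value 100 mg/kg.

Compound 3 stands level with compound 1 at the digits shown, the two of them together the lowest of the three numbers, and it lies furthest from compound 2. Going by the values given here, the only step between measured compounds that differ in one place is a 3.0-fold higher number from compound 1 to compound 2 (0.48 log units; beyond the scatter), a change on the aromatic ring, which is a different part of the molecule from the one now in question.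

Compound 4, `CC1CC(=O)N(CC(=O)N2CCN(c3cccc(C(F)(F)F)c3)CC2)C1=O`, is the next compound and has not yet been measured. It differs from compound 3 in one place: hydrogen in place of ethyl on a saturated ring carbon. Among the compounds with values here, no measured pair shows what removing the ethyl from the saturated ring carbon does, so there is no direct guide. Within the data shown here, the one known step concerns the aromatic ring only and says nothing about this position. With nothing to point either way, the expectation for compound 4 is a step of about no change at the digits printed from compound 3 to compound 4 (within the scatter), that is, no change beyond the scatter. Compound 4 is therefore expected to give in this assay about 100 mg/kg, within a range from 50 mg/kg to 300 mg/kg.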

Compound 4, minimum effective dose: 100 mg/kg
Estimate against measurement, compound 4: no gap at the digits printed, and the stated range covers the measured number.
By their numbers in this assay, from the lowest: compounds 1, 3 and 4 (each within the scatter of the next); then compound 2.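

In this assay, the step on the saturated ring carbon reads no change at the digits printed from compound 3 to compound 4 (within the scatter), so in this pair the ethyl, two ring bonds from the ring nitrogen, can give way to hydrogen without a change beyond the scatter. Compound 4 also links this series to the aromatic ring comparison: trifluoromethyl in place of hydrogen gives a 3.0-fold lower number from compound 2 to compound 4 (0.48 log units; beyond the scatter), in line with the effect of chloro in place of hydrogen seen in the reverse of a 3.0-fold higher number from compound 1 to compound 2 (0.48 log units; beyond the scatter), while trifluoromethyl in place of chloro gives no change at the digits printed from compound 1 to compound 4 (within the scatter). Nothing given here explains why either change has the effect it has.

On these data alone, the ethyl-to-hydrogen step has been read only with trifluoromethyl on the aromatic ring, so it remains open whether it would hold with chloro or with hydrogen there, or what a longer chain such as butyl would do on the same ring carbon. As far as these compounds go, it is also open how a polar replacement such as an amine or a carboxylic acid would fare at that carbon, or what would follow if the remaining methyl there gave way to hydrogen.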